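A few compounds are considered here, and "the series" means these few. Any claim that something is new, unique, unknown or untested is made for them only; others in the source may bear on it.

Of the compounds shown here, three of one family have been measured in a functional assay on NCI-H727 cells (Homo sapiens), read by fluorescence and BrdU incorporation, with a stated time of 48 h, tested at 10 uM (a higher number here means a weaker effect of the compound at the concentration tested, a lower number a stronger effect), and a fourth is still open. Compound 1 `COc1cc(OC)c(C(=O)/C=C/c2ccccc2SC)c(OC)c1` gives 35% in this assay. Compound 2 `COc1cccc(/C=C/C(=O)c2c(OC)cc(OC)cc2OC)c1` shares the core of compound 1 and differs from it only in the part counted here: 3-methoxyphenyl in place of 2-(methylsulfanyl)phenyl on a double-bonded chain carbon bound to a double-bonded chain carbon. In this assay compound 2 gives 37%, and the two numbers differ by a number 2 percentage points higher from compound 1 to compound 2 (within the scatter). Compound 3 `COc1cc(O)c(C(=O)/C=C/c2ccccc2SC)c(OC)c1` is compound 1 with one small change, (hydrogen in place of methyl on an oxygen on an aromatic ring), and in this assay compound 3 gives 43%. That change moved the read-out by a number 8 percentage points higher from compound 1 to compound 3 (within the scatter), so the two values cannot be told apart.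

Compound 4 `COc1cccc(/C=C/C(=O)c2c(O)cc(OC)cc2OC)c1` has not yet been measured. It stands to compound 2 exactly as compound 3 stands to compound 1: the change is hydrogen in place of methyl on an oxygen on an aromatic ring, the same change at the same place, on an oxygen on an aromatic ring whose other neighbours are aromatic carbon. Going by the values given here, because the only example of this change so far gave a number 8 percentage points higher from compound 1 to compound 3 (within the scatter), the step from compound 2 to compound 4 is expected to be about as small, a number 8 percentage points higher from compound 2 to compound 4 (within the scatter), and to stay within the scatter. That expectation rests on a single pair of compounds, and the second core could respond differently. For compound 4 the estimate in this assay is 45%, with a likely range from 32% to 58%.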

Compound 4, a percentage reported as activity, at one concentration (the size of the read-out at that concentration, not a potency): 35%
Estimate against measurement, compound 4: 10 percentage points above, within the range that was stated.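

On the core of compound 2, the change from methoxy to hydroxy gives a number 2 percentage points lower from compound 2 to compound 4 (within the scatter) in this assay, so this pair, like the first, cannot be told apart. Carried from one core to the other, the change therefore shows no difference that this read-out can detect, and on both cores the hydroxy compound reads like its methoxy partner: the same change on two cores in this assay, a number 8 percentage points higher (within the scatter) from compound 1 to compound 3 and a number 2 percentage points lower (within the scatter) from compound 2 to compound 4, 10 percentage points apart, within the scatter of two such steps This does not show that the change has no effect at all, since a small real effect could hide inside the scatter, and a read-out at one concentration is not a potency; two pairs also say nothing about how the change would behave on any third core.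

The compounds shown carry only a methyl or a hydrogen on this oxygen, which leaves open whether a longer chain on it, or an amine in place of the whole methoxy or hydroxy group, would give a read-out that can be told apart from these. On the other side of the molecule, only 3-methoxyphenyl and 2-(methylsulfanyl)phenyl appear, so a phenyl ring bearing a carboxylic acid remains an open case as well.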